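The source may report more compounds than this note shows. Statements on the series, on what has been measured and on what is new or still open speak of the compounds shown alone.

The question is whether a change at one spot on a shared core alters how strongly a compound harms cells. In an ADME assay on Vero cells (Chlorocebus sabaeus) for cytotoxicity, read by microscopy, with a stated time of 6 days (on this read-out lower numbers stand for higher toxicity in this test and higher numbers for lower toxicity in this test), compound 1, with the structure `CCCCCNc1cnc(C(=O)NCc2ccccc2)cn1`, gives > 100000 nM, which is a limit of the test rather than a number. Compound 2, `CCCCCCCCNc1nccnc1C(=O)NCc1ccccc1`, also reaches only the limit of > 100000 nM in this assay. Compound 3, `O=C(NCc1ccccc1)c1nccnc1Cl`, has no result in this assay; its entry reads "not determined" (no result reported). The only footing for any expectation is therefore what compound 1 and compound 2 show: the limit of > 100000 nM in this assay, at which 2 of the 3 values shown sit.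

Compound 4 is `CCCCCNc1nccnc1C(=O)NCc1ccccc1`. From compound 3 to compound 4 the change is pentylamino in place of chloro on an aromatic carbon. No measured pair of compounds differing in one place exists in this assay, so the size of this step cannot be read from any step shown. Compound 1 and compound 2 both carry an alkylamino group, as compound 4 does, and both sit at the limit, so the expectation is that compound 4 shows no measurable harm within the range of this assay. Compound 4 is therefore expected to give 100000 nM in this assay, with a likely span from 50000 nM to 200000 nM, and most probably reported only as a limit.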

Compound 4, minimum cytotoxic concentration: > 100000 nM
Compound 4 ended at the assay's limit; the forecaster's own chance of this, stated with the estimate: 85%; the middle value lies on the limit itself.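

Going by these compounds alone, compound 2 and compound 4 both end at a limit rather than a number, so no step between them can be read in this assay. The same holds across the series: the limit of > 100000 nM in this assay, at which 3 of the 4 values shown sit.

The compounds shown leave open whether any change at one spot on the shared core alters harm to cells.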